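Halogenated benzyl adenosines in a cell growth assay

A few compounds are considered here, and "the series" means these few. Any claim that something is new, unique, unknown or untested is made for them only; others in the source may bear on it.

Compound 1 `OC[C@H]1O[C@@H](n2cnc3c(NCc4ccc(F)cc4)ncnc32)[C@H](O)[C@@H]1O`: > 166000 nM
Compound 2 `OC[C@H]1O[C@@H](n2cnc3c(NCc4ccc(Cl)cc4)ncnc32)[C@H](O)[C@@H]1O`: > 166000 nM
Compound 3 `COc1cccc(CNc2ncnc3c2ncn3[C@@H]2O[C@H](CO)[C@@H](O)[C@H]2O)c1`: "not determined" (no result reported)

Three ribosides sharing one core were examined in a functional assay on G-361 cells (Homo sapiens) for antiproliferative activity, with a stated time of 72 h; on this read-out higher numbers stand for weaker inhibition and lower numbers for stronger inhibition. Compound 1 `OC[C@H]1O[C@@H](n2cnc3c(NCc4ccc(F)cc4)ncnc32)[C@H](O)[C@@H]1O` reached only a limit of the assay, giving > 166000 nM. Compound 2 `OC[C@H]1O[C@@H](n2cnc3c(NCc4ccc(Cl)cc4)ncnc32)[C@H](O)[C@@H]1O` likewise reached only a limit, giving > 166000 nM. The step that the two limits leave unreadable from compound 1 to compound 2 therefore cannot be read. For compound 3 `COc1cccc(CNc2ncnc3c2ncn3[C@@H]2O[C@H](CO)[C@@H](O)[C@H]2O)c1` no number exists at all; its entry in this assay reads "not determined" (no result reported). Compound 3 therefore stands nowhere on the scale. The other two values are limits (the limit of > 166000 nM in this assay, at which 2 of the 3 values shown sit).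

Compound 4 `OC[C@H]1O[C@@H](n2cnc3c(NCc4ccc(F)c(Cl)c4)ncnc32)[C@H](O)[C@@H]1O` differs from compound 3 by 3-chloro-4-fluorophenyl in place of 3-methoxyphenyl on a saturated chain carbon bound to a nitrogen on an aromatic ring. For the measured compounds named here, no measured step bears directly on this change: the only counted step, from a fluoro to a chloro analogue, is unreadable, and compound 3 itself has no value. What can be said is that the two halogenated benzyl analogues both sit at the limit (the limit of > 166000 nM in this assay, at which 2 of the 3 values shown sit), and compound 4 carries a benzyl bearing both of those halogens. Compound 4 is therefore expected to give about 200000 nM, within roughly 50000 nM to 1000000 nM, most likely again reported only as a limit.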

Compound 4, half-maximal inhibitory concentration: > 166000 nM
Compound 4 ended at the assay's limit; the forecaster's own chance of this, stated with the estimate: 85%; the middle value lies beyond the limit too.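

The steps from compound 1 and from compound 2 to compound 4 cannot be read in this assay, as all three compounds stand at one limit: the limit of > 166000 nM in this assay, at which 3 of the 4 values shown sit.

The compounds shown leave open whether these benzyl groups differ at all in antiproliferative activity, and where compound 3 stands among them.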